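Extending the Alkyl Chain from Compound 3 to Compound 4

The compounds below may be only part of what the source reports. "The series", "measured", "known", "first", "only" and "open" are said of these compounds alone.

Three measured compounds share one core and differ only in the length of a saturated chain attached to a sulfur. Compound 1 `CCCCCCCCSC(=O)CS(=O)(=O)Nc1c(C(C)C)cccc1C(C)C` gives 150 nM in an assay on microsomes from intestine for inhibition of acyl-CoA:cholesterol acyltransferase (Oryctolagus cuniculus); on this read-out higher numbers stand for weaker inhibition and lower numbers for stronger inhibition. Compound 2 `CCCCCCCCCCSC(=O)CS(=O)(=O)Nc1c(C(C)C)cccc1C(C)C` gives 130 nM in this assay, and compound 3 `CCCCCCCCCCCCSC(=O)CS(=O)(=O)Nc1c(C(C)C)cccc1C(C)C` gives 73 nM in this assay. Compound 3 thus holds the lowest of the three numbers; its gap to compound 2 lies within the scatter, whereas the step of a 2.1-fold lower number from compound 1 to compound 3 (0.31 log units; beyond the scatter) lies beyond it.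

Compound 4 `CCCCCCCCCCCCCCSC(=O)CS(=O)(=O)Nc1c(C(C)C)cccc1C(C)C` lengthens the chain once more: ethyl in place of hydrogen on a saturated chain carbon, ten or more bonds along the chain from a sulfur. For the measured compounds named here, two measured steps bear on this change. The step of a 1.2-fold lower number from compound 1 to compound 2 (0.06 log units; within the scatter) and the step of a 1.8-fold lower number from compound 2 to compound 3 (0.25 log units; within the scatter) each added ethyl to the chain, and each stayed within the scatter on its own, even though together they make up the step from compound 1 to compound 3. Whether further lengthening carries this drift onward cannot be told from three compounds alone. The expectation for compound 4 in this assay is therefore a small lowering of the number, a 1.5-fold lower number from compound 3 to compound 4 (0.16 log units; within the scatter), most likely within the scatter. Compound 4 is estimated at 50 nM, with a range from 25 nM to 110 nM.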

Compound 4, half-maximal inhibitory concentration: 36 nM
Compound 4: the middle estimate sits 1.4-fold (0.14 log units) above what was measured; measured number inside the range.
By their numbers in this assay, from the lowest: compound 4; then compounds 3, 2 and 1 (each within the scatter of the next, the first and the last beyond it).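

For the compounds shown here, compound 4 gives the first single ethyl step that lies beyond the scatter in this assay, a 2.0-fold lower number from compound 3 to compound 4 (0.31 log units; beyond the scatter), so one such addition can now be read on its own. Compound 4 also stands apart from the two shorter chains, a 3.6-fold lower number from compound 2 to compound 4 (0.56 log units; beyond the scatter) and a 4.2-fold lower number from compound 1 to compound 4 (0.62 log units; beyond the scatter), and the butyl change keeps a similar size wherever it can be compared: the same change on two cores in this assay, a 2.1-fold lower number (0.31 log units; beyond the scatter) from compound 1 to compound 3 and a 3.6-fold lower number (0.56 log units; beyond the scatter) from compound 2 to compound 4, 1.8-fold (0.24 log units) apart, within the scatter of two such steps The ethyl step on the longest chains looks larger than the first one, yet the two cannot be told apart, so the series does not show that the effect of ethyl depends on chain length: the same change on two cores in this assay, a 1.2-fold lower number (0.06 log units; within the scatter) from compound 1 to compound 2 and a 2.0-fold lower number (0.31 log units; beyond the scatter) from compound 3 to compound 4, 1.8-fold (0.24 log units) apart, within the scatter of two such steps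

The compounds shown stop at the chain of compound 4, so they leave open whether a longer chain, such as hexadecyl, would lower the number further or reverse the trend. They also leave open whether a branched chain, or a chain ending in a carboxylic acid or an amine, would be tolerated at this position.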